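A few compounds are considered here, and "the series" means these few. Any claim that something is new, unique, unknown or untested is made for them only; others in the source may bear on it.

Measured compounds:
- compound 1, `COc1ccc2c(=O)c(/C=C/C(=O)Nc3cccc(C)c3)coc2c1`: > 100000 nM
- compound 2, `COc1ccc2c(=O)c(/C=C/C(=O)Nc3ccccc3)coc2c1`: 51000 nM
- compound 3, `O=C(/C=C/c1coc2cc(O)ccc2c1=O)NCc1ccc(F)cc1`: > 100000 nM

Going by the values given here, in a functional assay on A549 cells (Homo sapiens) for inhibition, read by MTT assay, with a stated time of 48 h (on this read-out lower numbers stand for stronger inhibition and higher numbers for weaker inhibition), compound 2 gives 51000 nM, the only true number among the three values shown. Compound 1 sits at a limit of the assay, > 100000 nM. Compound 3 likewise sits at a limit, > 100000 nM. Among the compounds with values here, the one measured step, hydrogen in place of methyl on an aromatic carbon, gives an at least 1.9-fold lower number from compound 1 to compound 2 (0.29 log units; that floor lies within the scatter); it is bounded by the limit of > 100000 nM in this assay, at which 2 of the 3 values shown sit.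

Compound 4, `COc1ccc(CNC(=O)/C=C/c2coc3cc(OC)ccc3c2=O)cc1`, differs from compound 2 by 4-methoxybenzyl in place of phenyl on an amide-type nitrogen. Within the data shown here, no measured step touches this change; compound 3, which also carries a benzyl group on the amide nitrogen, shows only a limit. Compound 4 is therefore expected to stay weak, at roughly 80000 nM, between 25000 nM and 300000 nM. The expected step is a 1.6-fold higher number from compound 2 to compound 4 (0.20 log units; within the scatter).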

Compound 4, half-maximal inhibitory concentration: 22500 nM
Beside the measured number, compound 4's estimate is 3.6-fold (0.55 log units) above it; measured number below the stated range.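

In this assay, 4-methoxybenzyl in place of phenyl on the amide-type nitrogen gives a 2.3-fold lower number from compound 2 to compound 4 (0.36 log units; beyond the scatter), so a change at this nitrogen moves the number by more than the usual scatter, and a larger group here does not abolish the effect. Measured against 3-methylphenyl on the same nitrogen, the change gives an at least 4.4-fold lower number from compound 1 to compound 4 (0.64 log units; beyond the scatter), and this step is only a floor: the limit of > 100000 nM in this assay, at which 2 of the 4 values shown sit.

The compounds shown leave open whether the methoxy group or the benzyl link accounts for the lower number. They also leave open how an amine or a longer chain on this nitrogen would read.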